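Lengthening the side chain once more on a shared core

The compounds below may be only part of what the source reports. "The series", "measured", "known", "first", "only" and "open" are said of these compounds alone.

Values measured so far in a functional assay on SW480 cells (Homo sapiens) for antiproliferative activity, read by MTT assay, with a stated time of 48 h (on this read-out lower numbers stand for stronger inhibition and higher numbers for weaker inhibition), are these
Compound 1 `CCC(CCO)n1cnc2c(Cl)nc(F)nc21` gives 19800 nM
Compound 2 `CCCC(CCO)n1cnc2c(Cl)nc(F)nc21` gives 17200 nM

Within the data shown here, compound 2 stands at 17200 nM and cannot be told apart from compound 1, its only measured neighbour. Among the measured compounds shown here, the single measured step is a 1.2-fold lower number from compound 1 to compound 2 (0.06 log units; within the scatter) and it puts methyl in place of hydrogen on a saturated chain carbon, three bonds along the chain from an aromatic nitrogen. Compound 3 `CCCCC(CCO)n1cnc2c(Cl)nc(F)nc21` repeats that kind of change, and the difference is methyl in place of hydrogen on a saturated chain carbon, four bonds along the chain from an aromatic nitrogen in a chain that goes from propyl to butyl. One step is thin evidence, and nothing measured yet shows how a chain of this length behaves. For the measured compounds named here, the only guide is the step of a 1.2-fold lower number from compound 1 to compound 2 (0.06 log units; within the scatter) and its small size, so no step beyond the scatter is expected in this assay for the new compound. The expected change is a 1.1-fold lower number from compound 2 to compound 3 (0.06 log units; within the scatter) and its direction is only weakly supported. For compound 3 the estimated value is 15000 nM with an expected range from 8000 nM to 26000 nM in repeat measurements.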

Compound 3, half-maximal inhibitory concentration: 13200 nM
Compound 3: the middle estimate sits 1.1-fold (0.06 log units) above what was measured; the measured number falls inside the stated range.
By their numbers in this assay, from the lowest: compounds 3, 2 and 1 (each within the scatter of the next).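

In this assay, the change from propyl to butyl gives a step (a 1.3-fold lower number from compound 2 to compound 3 (0.11 log units; within the scatter)), so a second lengthening of the side chain, now four bonds along the chain from an aromatic nitrogen, also stays within the usual scatter of repeated measurements. The wider span is the new information: the two additions taken together make a larger change (a 1.5-fold lower number from compound 1 to compound 3 (0.18 log units; within the scatter)), and even this stays within the scatter. Compounds 1, 2 and 3 therefore cannot be told apart in this assay, and across these three chain lengths the added carbons show no measurable effect on the read-out.

No supporting measurement is available to explain this result. Going by these compounds, it remains open whether a longer chain than butyl, or an amine or a carboxylic acid in place of the chain, would give a step beyond the scatter in this assay.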